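Methylsulfonyl on the benzamide of a weak antiproliferative

The compounds below may be only part of what the source reports. "The series", "measured", "known", "first", "only" and "open" are said of these compounds alone.

The shared core carries an amide on the aniline; compound 1 `Cc1nc(C(=O)Nc2ccc(Cl)c(-c3nnc4c(Cl)cccn34)c2)cs1` bears a 2-methyl-1,3-thiazol-4-yl on the carbonyl carbon, compound 2 `O=C(Nc1ccc(Cl)c(-c2nnc3c(Cl)cccn23)c1)c1ccccc1` a plain phenyl. In a functional assay on HeLa cells (Homo sapiens) for antiproliferative activity, read by MTT assay, with a stated time of 72 h (on this read-out higher numbers stand for weaker inhibition and lower numbers for stronger inhibition), compound 1 gives 79800 nM. Compound 2 reaches only the limit of this assay, > 100000 nM. The step of an at least 1.2-fold higher number from compound 1 to compound 2 (0.09 log units; that floor lies within the scatter) is therefore at least a small rise that stays within the scatter, so compound 2 stands at the weak end of the two values shown, no more than even with compound 1; the limit of > 100000 nM in this assay, at which 1 of the 2 values shown sits, is where it sits.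

Compound 3 `CS(=O)(=O)c1cccc(C(=O)Nc2ccc(Cl)c(-c3nnc4c(Cl)cccn34)c2)c1` differs from compound 2 by methylsulfonyl in place of hydrogen on an aromatic carbon. No measured step touches a methylsulfonyl group, and the only step shown, from a thiazolyl to a phenyl, was within the scatter, so there is no ground for expecting a shift beyond the scatter in either direction in this assay. Compound 3 is thus expected to remain near the limit, with an estimated a number no higher from compound 2 to compound 3 (the limit leaves the size open). The estimate for compound 3 is 100000 nM, within 30000 nM to 300000 nM.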

Compound 3, half-maximal inhibitory concentration: 86400 nM
Beside the measured number, compound 3's estimate is 1.2-fold (0.06 log units) above it; measured number inside the range.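

In this assay, among these compounds, methylsulfonyl on the phenyl ring, meta to a large group, gives an at least 1.1-fold lower number from compound 2 to compound 3 (0.06 log units; that floor lies within the scatter) as the only reading of this change. From the compounds shown here alone, compound 2 stands at a limit of the assay, so only that floor can be read and the full size of the step stays open: the limit of > 100000 nM in this assay, at which 1 of the 3 values shown sits. The other comparison has no limit in it: the 3-(methylsulfonyl)phenyl in place of the thiazolyl gives a 1.1-fold higher number from compound 1 to compound 3 (0.03 log units; within the scatter) on the carbonyl carbon, so compound 1 and compound 3 cannot be told apart here, and adding methylsulfonyl at this place brings no measured separation from the thiazolyl amide.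

The compounds shown leave open whether an amine or a carboxylic acid at the same aromatic carbon would move the number beyond the scatter, and whether a longer chain on the sulfonyl group would do so. They also leave open whether methylsulfonyl would read the same at another carbon of the ring.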